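Benzoyl ring exchanges on a boronic chalcone series

This account rests on a few compounds, and the source may have more. Where it says the series, first, only, none or still open, it means among the compounds named here.

Going by the values given here, compound 1 `O=C(/C=C/c1ccc2c(c1)B(O)OC2)c1ccc(Br)cc1` gives 9500 nM in a functional assay on MDA-MB-231 cells (Homo sapiens) for cytotoxicity, read by MTT assay, with a stated time of 48 h (on this read-out higher numbers stand for weaker inhibition and lower numbers for stronger inhibition), the lowest number of the three so far, though both others sit within the scatter of it. Compound 2 `CSc1ccc(C(=O)/C=C/c2ccc3c(c2)B(O)OC3)cc1` gives 9800 nM and compound 3 `O=C(/C=C/c1ccc2c(c1)B(O)OC2)c1ccc([N+](=O)[O-])cc1` gives 11200 nM in this assay; the steps of a 1.0-fold higher number from compound 1 to compound 2 (0.01 log units; within the scatter), a 1.2-fold higher number from compound 1 to compound 3 (0.07 log units; within the scatter) and a 1.1-fold higher number from compound 2 to compound 3 (0.06 log units; within the scatter) all stay within the scatter. Compound 4 `O=C(/C=C/c1ccc2c(c1)B(O)OC2)c1ccccc1O` is not yet measured; it differs from compound 1 by 2-hydroxyphenyl in place of 4-bromophenyl on a carbonyl carbon. The three measured steps each swap a single group on that ring and none moved the number beyond the scatter, so for compound 4 a step of no change at the digits printed from compound 1 to compound 4 (within the scatter) is expected. Compound 4 is therefore estimated at 9500 nM in this assay, within 4000 nM to 22000 nM.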

Compound 4, half-maximal inhibitory concentration: 16900 nM
Estimate against measurement, compound 4: 1.8-fold (0.25 log units) below; low and high end bracket the measured number.
By their numbers in this assay, from the lowest: compounds 1, 2, 3 and 4 (each within the scatter of the next).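

With 2-hydroxyphenyl in place of 4-bromophenyl on a carbonyl carbon, a 1.8-fold higher number from compound 1 to compound 4 (0.25 log units; within the scatter) in this assay. Exchanging the whole aryl group, with an entering group that counts a hydrogen-bond donor and acceptor where the leaving group counts none, therefore still leaves this series within the scatter. No measured property available here bears on this result.

Since the substituent and its place differ together in this step, their contributions cannot be separated. From the compounds shown here alone, whether an amine or a carboxylic acid on this ring would take the number beyond the scatter remains open.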